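From Phenethyl to Naphthalen-1-yl: Expected Solubility of Compound 3

The compounds below may be only part of what the source reports. "The series", "measured", "known", "first", "only" and "open" are said of these compounds alone.

Measured compounds:
compound 1 `COc1ccc(F)cc1CNCCCNc1ccnc2cc(CCc3ccccc3)ccc12` — 4200 nM
compound 2 `COc1cccc(CNCCCNc2ccnc3cc(Oc4ccccc4)ccc23)c1O` — 14500 nM

In a physicochemical assay for solubility, with a stated time of 18 h, at pH 7.4 (a lower number here means a less soluble compound, a higher number a more soluble compound), compound 1 stands lowest of the two numbers; compound 2 gives the higher number, and the gap between them lies beyond the scatter. Compound 3 `COc1ccc(F)cc1CNCCCNc1ccnc2cc(-c3cccc4ccccc34)ccc12` differs from compound 1 in one place: naphthalen-1-yl in place of phenethyl on an aromatic carbon. For the measured compounds named here, no measured pair shows this change, so its effect is expected rather than known. A modest downward step a 2.1-fold lower number from compound 1 to compound 3 (0.32 log units; beyond the scatter) is expected. Compound 3 is therefore estimated at 2000 nM, within 500 nM to 8000 nM.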

Compound 3, solubility: 32000 nM
The estimate for compound 3 lay 16-fold (1.20 log units) below the measured number, outside the stated range (above it).
By their numbers in this assay, from the lowest: compound 1; then compound 2; then compound 3.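

In this assay, the aromatic carbon meta to a fused ring and para to a fused ring proves sensitive to the group it carries: naphthalen-1-yl in place of phenethyl gives a 7.6-fold higher number from compound 1 to compound 3 (0.88 log units; beyond the scatter), a rise beyond the scatter. The number goes up even though the entering group has more heavy atoms and a second aromatic ring. Nothing available accounts for this rise. The compounds shown leave open whether a simple phenyl at this carbon would behave like naphthalen-1-yl or like phenethyl. They also leave open what an amine or a carboxylic acid on the entering rings would do.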